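The source may hold more compounds than are shown below. What is called first, only, known or untested is meant among the compounds shown, and "the series" means these compounds.

Three compounds have been measured in a functional assay on DU-145 cells (Homo sapiens) for antiproliferative activity, read by MTT assay, with a stated time of 24 h; on this read-out lower numbers stand for stronger inhibition and higher numbers for weaker inhibition:
compound 1 `COc1ccc(C(=O)/C=C/c2cc(-c3cc(OC)c(OC)c(OC)c3)n3nc(-c4ccccc4)cc3n2)cc1` gives 25200 nM;
compound 2 `COc1ccc(/C=C/C(=O)c2cc(-c3ccc(OC)c(OC)c3)n3nc(-c4ccccc4)cc3n2)cc1` gives 14900 nM;
compound 3 `COc1cc(-c2cc(C(=O)/C=C/c3ccccc3)nc3cc(-c4ccccc4)nn23)cc(OC)c1OC` gives 16300 nM.

Compound 2 shows the lowest of the three numbers, yet its gaps to compound 3 and to compound 1 both lie within the scatter, so no order among the three can be read from them. Compound 4 `COc1ccc(-c2cc(/C=C/C(=O)c3ccc(C)cc3)nc3cc(-c4ccccc4)nn23)cc1OC` differs from compound 2 in one place: 2-((4-methylphenyl)carbonyl)ethenyl in place of (2-(4-methoxyphenyl)ethenyl)carbonyl on an aromatic carbon. Among the measured compounds shown here, one measured step bears on this, since it likewise turns the chalcone-type chain around and removes a methoxy group: a 1.5-fold lower number from compound 1 to compound 3 (0.19 log units; within the scatter). That step stayed within the scatter, so in this assay no step beyond the scatter is expected, a 1.0-fold higher number from compound 2 to compound 4 (0.00 log units; within the scatter). Compound 4 is therefore estimated at 15000 nM. Compound 4 is expected to fall between 6000 nM and 38000 nM.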

Compound 4, half-maximal inhibitory concentration: 26800 nM
Compound 4: middle estimate off by 1.8-fold (0.25 log units), on the low side; measured number inside the range.
By their numbers in this assay, from the lowest: compounds 2, 3, 1 and 4 (each within the scatter of the next).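

On this aromatic carbon in this assay, 2-((4-methylphenyl)carbonyl)ethenyl in place of (2-(4-methoxyphenyl)ethenyl)carbonyl gives a 1.8-fold higher number from compound 2 to compound 4 (0.25 log units; within the scatter). Alongside the earlier step, this shows that the same kind of swap also stays within the scatter with a 3,4-dimethoxyphenyl group on the core, not only with the trimethoxyphenyl group of compound 1 and compound 3. Nothing available explains this result.
Going by these compounds, the turning of the chain and the exchange of methoxy for methyl come together here, so their separate contributions remain open. Also open, on these data alone, is whether an amine or a carboxylic acid on the chain's phenyl ring would give a step beyond the scatter.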